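Compound 3 and an isomeric amide chain

The source may report more compounds than this note shows. Statements on the series, on what has been measured and on what is new or still open speak of the compounds shown alone.

Measured in a functional assay on MCF7 cells (Homo sapiens) for antiproliferative activity, read by MTT assay, with a stated time of 24 h; on this read-out lower numbers stand for stronger inhibition and higher numbers for weaker inhibition:
Compound 1 `CCn1c(C(=O)N[C@@H](CC(=O)OC)C(=O)OC)ccc1C(CC)(CC)c1ccc(OCS(=O)(=O)c2ccccc2)c(C)c1`: > 50000 nM, a limit of the assay
Compound 2 `CCn1c(C(=O)NCCO)ccc1C(CC)(CC)c1ccc(OCS(=O)(=O)c2ccccc2)c(C)c1`: 15500 nM
Compound 3 `CCn1c(C(=O)N[C@H](C)CO)ccc1C(CC)(CC)c1ccc(OCS(=O)(=O)c2ccccc2)c(C)c1`: 10600 nM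

Compound 3, at 10600 nM, stands level with compound 2 within the scatter, and both lie well clear of compound 1, as an at least 3.2-fold lower number from compound 1 to compound 2 (0.50 log units; beyond the scatter) and an at least 4.7-fold lower number from compound 1 to compound 3 (0.67 log units; beyond the scatter) show. Compound 4 `CCn1c(C(=O)NCCCO)ccc1C(CC)(CC)c1ccc(OCS(=O)(=O)c2ccccc2)c(C)c1` carries 3-hydroxypropyl in place of 1-(hydroxymethyl)ethyl on an amide-type nitrogen. The closest measured change is a 1.5-fold lower number from compound 2 to compound 3 (0.17 log units; within the scatter), so no step beyond the scatter is expected in this assay. The expected result is a 1.1-fold higher number from compound 3 to compound 4 (0.05 log units; within the scatter). Compound 4 is estimated at 12000 nM, with an expected range of 6000 nM to 25000 nM.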

Compound 4, half-maximal inhibitory concentration: 42000 nM
For compound 4 the middle estimate is 3.5-fold (0.54 log units) below the measured one; measured number outside the range, above it.
By their numbers in this assay, from the lowest: compounds 3 and 2 (each within the scatter of the next); then compound 4. At a limit, above all of these: compound 1.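

In this assay, 3-hydroxypropyl in place of 1-(hydroxymethyl)ethyl on the amide-type nitrogen joins the same atoms differently and does not give the same result, with a 4.0-fold higher number from compound 3 to compound 4 (0.60 log units; beyond the scatter). Extending the chain also counts, with hydroxymethyl in place of hydroxy giving a 2.7-fold higher number from compound 2 to compound 4 (0.43 log units; beyond the scatter), so this position responds to how the chain is arranged as well as to what it contains. Compound 1 stands at a limit: the limit of > 50000 nM in this assay, at which 1 of the 4 values shown sits. Only a floor can be given for the remaining step, an at least 1.1-fold lower number from compound 1 to compound 4 (0.07 log units; that floor lies within the scatter), and it cannot be read beyond that.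

The compounds shown leave open how an amine or a carboxylic acid in place of the hydroxy would read here. They also leave open whether a longer chain would raise the number further.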